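The source may hold more compounds than are shown below. What is called first, only, known or untested is meant among the compounds shown, and "the series" means these compounds.

Three compounds were examined in an assay on isolated protein for binding affinity to corticotropin-releasing factor receptor 1 (Homo sapiens); a higher number here means a weaker inhibitor, a lower number a stronger inhibitor. Compound 1 `CCN(c1nc(C)cc(C)n1)c1c(Br)cc(OC)cc1OC` gives 12 nM. Compound 2 `CCN(CC)c1cc(C)nc(N(CC)c2c(Br)cc(OC)cc2OC)n1` gives 48 nM. Compound 3 `CCN(CC)c1cc(C)nc(N(CC)c2ccc(N(C)C)cc2C(F)(F)F)n1` gives 11 nM, a number within the scatter of compound 1 but well apart from compound 2; how the core of compound 3 differs from that of compound 2 is not broken down here. Compound 1 and compound 2 differ by methyl in place of diethylamino on an aromatic carbon, and in this assay that change gave a 4.0-fold lower number from compound 2 to compound 1 (0.60 log units; beyond the scatter).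

Compound 4 `CCN(c1nc(C)cc(C)n1)c1ccc(N(C)C)cc1C(F)(F)F` has not yet been measured. It differs from compound 3 by methyl in place of diethylamino on an aromatic carbon, the same change that separates compound 2 from compound 1. Because a 4.0-fold lower number from compound 2 to compound 1 (0.60 log units; beyond the scatter) in this assay, a comparable step, a 2.8-fold lower number from compound 3 to compound 4 (0.44 log units; beyond the scatter), is expected. Compound 4 is therefore estimated at 4 nM, expected to fall between 1.5 nM and 12 nM.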

Compound 4, inhibition constant: 68 nM
Estimate against measurement, compound 4: 17-fold (1.23 log units) below; measured number above the stated range.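

In this assay, methyl in place of diethylamino on an aromatic carbon gave a 6.2-fold higher number from compound 3 to compound 4 (0.79 log units; beyond the scatter), and the two cores answer this change in opposite directions: the same change on two cores in this assay, a 4.0-fold lower number (0.60 log units; beyond the scatter) from compound 2 to compound 1 and a 6.2-fold higher number (0.79 log units; beyond the scatter) from compound 3 to compound 4, 25-fold (1.39 log units) apart, beyond the scatter of two such steps

This shows that, across these two pairs, the effect of the change depends on the rest of the molecule, so a step read on one core cannot simply be carried to the other. It does not show which difference between the cores is responsible: compound 1 carries bromo and methoxy groups, compound 4 dimethylamino and trifluoromethyl, and two pairs set no rule for a third core.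

The compounds shown leave open which of those groups sets the direction of the step. They also leave open how a methylamino group or a propyl chain would read in that place on either core.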